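The compounds below may be only part of what the source reports. "The series", "measured", "known", "first", "only" and "open" are said of these compounds alone.

For the measured compounds named here, in a functional assay on MCF7 cells (Homo sapiens) for antiproliferative activity, with a stated time of 96 h (a higher number here means a weaker inhibitor, a lower number a stronger inhibitor), compound 1 (`Cc1cc(=O)oc2cc(OCC(=O)c3cccc(C(F)(F)F)c3)ccc12`) gives 38400 nM, the only number in this small set. Compound 2 (`COc1cccc(C(=O)COc2ccc3c(C(F)(F)F)cc(=O)oc3c2)c1`) has no number and is reported as "not active" (no number reported). Compound 3 (`O=C(COc1ccc2c(C(F)(F)F)cc(=O)oc2c1)c1cccc(C(F)(F)F)c1`) is also reported as "not active" (no number reported), so compound 2 shares its result with compound 3. Compound 4 (`O=C(COc1ccc2c(C(F)(F)F)cc(=O)oc2c1)c1ccc(F)cc1`) changes one group of compound 2, (4-fluorophenyl in place of 3-methoxyphenyl on a carbonyl carbon), placing 4-fluorophenyl in place of 3-methoxyphenyl on a carbonyl carbon. Going by the values given here, no measured pair shows this change, so no step beyond the scatter is expected in this assay, and another result without a number is the likeliest outcome. If a number is reported, compound 4 is estimated at 60000 nM, within an expected range of 20000 nM to 150000 nM.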

Compound 4, half-maximal inhibitory concentration: "not active" (no number reported)
For compound 4 the study gives words and no number; no gap can be computed for the estimate.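

In this assay compound 2 and compound 4 are both reported as "not active" with no number, so no step can be read between them. Nothing measured here offers an explanation. Still open, on these data alone, is how far 4-fluorophenyl in place of 3-methoxyphenyl changes activity.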